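A Second Fluoro on the Benzyl Ring of Compound 2

A few compounds are considered here, and "the series" means these few. Any claim that something is new, unique, unknown or untested is made for them only; others in the source may bear on it.

Compound 2 `O=C(O)CN1C(=O)/C(=C/c2nc3ccccc3n2Cc2ccc(F)cc2)SC1=S` is one of three compounds tested in a functional assay on A549 cells (Homo sapiens) for cytotoxicity, read by MTT assay, with a stated time of 48 h (on this read-out higher numbers stand for weaker inhibition and lower numbers for stronger inhibition), where compound 2 gives 3570 nM. Compound 1 `O=C(O)CN1C(=O)/C(=C/c2nc3ccccc3n2Cc2ccc([N+](=O)[O-])cc2)SC1=S` gives 11400 nM, and compound 3 `O=C(O)CN1C(=O)/C(=C/c2nc3ccccc3n2Cc2ccc(Cl)cc2)SC1=S` gives 17500 nM. Compound 2 thus shows the lowest number of the three, and both steps away from it lie beyond the scatter: a 3.2-fold lower number from compound 1 to compound 2 (0.50 log units; beyond the scatter) and a 4.9-fold higher number from compound 2 to compound 3 (0.69 log units; beyond the scatter). Compound 4 `O=C(O)CN1C(=O)/C(=C/c2nc3ccccc3n2Cc2ccc(F)cc2F)SC1=S` differs from compound 2 in one place: fluoro in place of hydrogen on an aromatic carbon, so that 4-fluorobenzyl becomes 2,4-difluorobenzyl. Going by the values given here, none of the measured steps adds a group; each merely exchanges the group already present, so they give no direct guide to this change. Compound 4 is therefore expected to stay close to compound 2, with no step beyond the scatter, a 1.0-fold lower number from compound 2 to compound 4 (0.01 log units; within the scatter). The estimate for compound 4 is 3500 nM, with a range from 1400 nM to 9000 nM.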

Compound 4, half-maximal inhibitory concentration: 12800 nM
Estimate against measurement, compound 4: 3.7-fold (0.56 log units) below; measured number outside the range, above it.
By their numbers in this assay, from the lowest: compound 2; then compounds 1, 4 and 3 (each within the scatter of the next).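

In this assay, adding a fluoro ortho to a large group on the ring of compound 2 gives a 3.6-fold higher number from compound 2 to compound 4 (0.55 log units; beyond the scatter) and so shows that this added atom is not a silent change. The ring position therefore matters on this read-out, and 2,4-difluorobenzyl cannot be told apart from the other two groups, with a 1.4-fold lower number from compound 3 to compound 4 (0.14 log units; within the scatter) and a 1.1-fold higher number from compound 1 to compound 4 (0.05 log units; within the scatter) as the steps. Nothing measured here explains this step.

From the compounds shown here alone, whether a larger group at this same ring position, such as a methoxy group or an amine, would give a similar step stays open.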